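This account rests on a few compounds, and the source may have more. Where it says the series, first, only, none or still open, it means among the compounds named here.

Compound 1 `Oc1cccc(-c2cc(-c3ccccc3)cc(-c3ccsc3)n2)c1`: 10300 nM
Compound 2 `Oc1ccc(-c2cc(-c3ccccc3)cc(-c3ccsc3)n2)cc1`: 3600 nM

In a functional assay on HL-60 cells (Homo sapiens) for cytotoxicity, read by ELISA, with a stated time of 2 days (a higher number here means a weaker inhibitor, a lower number a stronger inhibitor), compound 2 holds the lower of the two numbers. Compound 3 `Oc1ccc(-c2cc(-c3ccccc3)cc(-c3ccc(O)cc3)n2)cc1` is next, and it differs from compound 2 in one place: 4-hydroxyphenyl in place of thiophen-3-yl on an aromatic carbon. There, 4-hydroxyphenyl stands in place of thiophen-3-yl, on an aromatic carbon next to the ring nitrogen.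

Going by the values given here, the only measured step is a 2.9-fold lower number from compound 1 to compound 2 (0.46 log units; beyond the scatter). That step concerns the hydroxyphenyl group, not the thiophen-3-yl place, so it bears on this change only indirectly. It shows that a single change in this series can give a modest shift. Among the compounds with values here, no measured compound reports on a change at the thiophen-3-yl place, so the direction stays uncertain, with only a slight lean towards a higher number. The expected move is a 1.4-fold higher number from compound 2 to compound 3 (0.14 log units; within the scatter), with no step beyond the scatter as the central expectation. For compound 3 the estimate is 5000 nM, with an expected range of 1500 nM to 17000 nM.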

Compound 3, half-maximal inhibitory concentration: 5700 nM
Compound 3: middle estimate off by 1.1-fold (0.06 log units), on the low side; measured number inside the range.
By their numbers in this assay, from the lowest: compounds 2, 3 and 1 (each within the scatter of the next, the first and the last beyond it).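

In this assay, going by these compounds alone, the first change at the aromatic carbon next to the ring nitrogen gives a 1.6-fold higher number from compound 2 to compound 3 (0.20 log units; within the scatter) and leaves thiophen-3-yl and 4-hydroxyphenyl indistinguishable at this position. The earlier compounds shown here varied only the hydroxyphenyl group, whereas this pair shows that a six-membered aromatic ring of carbon only, carrying 1 hydrogen-bond donor, can stand in place of a five-membered aromatic ring with 1 hetero atom without a step beyond the scatter. No measurement at hand offers an explanation for this result.

Still open, as far as these compounds go, is whether a group other than an aromatic ring, such as an amine, a carboxylic acid or a longer alkyl chain, would keep the number in the same range at this position. The compounds shown also do not separate the contribution of the hydroxyl group from that of the phenyl ring it sits on.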